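This account rests on a few compounds, and the source may have more. Where it says the series, first, only, none or still open, it means among the compounds named here.

Measured in a functional assay on HepG2 cells (Homo sapiens) for antiproliferative activity, read by MTT assay, with a stated time of 24 h; a higher number here means a weaker inhibitor, a lower number a stronger inhibitor:
- compound 1 `COc1cc(OC)c(-c2coc3cc(OCC=C(C)C)ccc3c2=O)cc1OC`: 280 nM
- compound 2 `COc1cccc(C(=O)Oc2ccc3c(=O)c(-c4cc(OC)c(OC)cc4OC)coc3c2)c1`: > 10000 nM, a limit of the assay
- compound 3 `COc1cc(OC)c(-c2coc3cc(OCc4ccccc4F)ccc3c2=O)cc1OC`: 1280 nM

Only compound 1 and compound 3 have true numbers in this assay, and the higher of the two belongs to compound 3, at 1280 nM.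

Next in the series is compound 4 `COc1cc(OC)c(-c2coc3cc(OCc4ccc(F)cc4)ccc3c2=O)cc1OC`, which carries 4-fluorophenyl in place of 2-fluorophenyl on a saturated chain carbon bound to an oxygen on an aromatic ring.

Two measured steps act at this oxygen substituent, and both exchange the whole group. The first, a 4.6-fold higher number from compound 1 to compound 3 (0.66 log units; beyond the scatter), is modest. The second, an at least 7.8-fold lower number from compound 2 to compound 3 (0.89 log units; beyond the scatter), is at least modest. Neither compares two fluorophenyl groups, so the effect of this change has not been tested directly. Compound 3 and compound 4 differ far less than the pair in a 4.6-fold higher number from compound 1 to compound 3 (0.66 log units; beyond the scatter), so a smaller step than that one is expected, most likely none beyond the scatter, with no direction favoured.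

The expected step is a 1.1-fold lower number from compound 3 to compound 4 (0.03 log units; within the scatter). For compound 4 the estimate is 1200 nM, with an expected range of 500 nM to 3000 nM.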

Compound 4, half-maximal inhibitory concentration: 1000 nM
Compound 4: the middle estimate sits 1.2-fold (0.08 log units) above what was measured; measured number inside the range.
By their numbers in this assay, from the lowest: compound 1; then compounds 4 and 3 (each within the scatter of the next). At a limit, above all of these: compound 2.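

In this assay, among these compounds, the exchange of 2-fluorobenzyl for 4-fluorobenzyl on the oxygen gives the first direct comparison of two fluorophenyl groups, and the step stays within the scatter (a 1.3-fold lower number from compound 3 to compound 4 (0.11 log units; within the scatter)). The gap to the 3-methylbut-2-en-1-yl group of compound 1 remains with the new isomer (a 3.6-fold higher number from compound 1 to compound 4 (0.55 log units; beyond the scatter)), so among the compounds shown, moving the fluorine does not close that gap. The step from the (3-methoxyphenyl)carbonyl group (an at least 10-fold lower number from compound 2 to compound 4 (1.00 log units; beyond the scatter)) starts from compound 2, whose value is a limit and not a number: the limit of > 10000 nM in this assay, at which 1 of the 4 values shown sits.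

The compounds shown leave open how an unsubstituted benzyl, a saturated 3-methylbutyl chain or a chain ending in an amine would read on this oxygen. A 3-methoxybenzyl group would also be needed to tell whether the limit seen for compound 2 goes with its carbonyl or with its 3-methoxyphenyl ring.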